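Swapping a phenyl group on a growth inhibitor

This account rests on a few compounds, and the source may have more. Where it says the series, first, only, none or still open, it means among the compounds named here.

Compound 1 `COc1ccc(C2=C(c3cc(OC)c(OC)c(OC)c3)CC3CCCN3C2=O)cc1O`: > 100000 nM, a limit of the assay and not a number
Compound 2 `COc1ccc(C2=C(c3ccc(SC)cc3)CC3CCCN3C2=O)cc1C`: 900 nM
Compound 3 `CSc1ccc(C2=C(c3ccc(F)c(F)c3)C(=O)N3CCCC3C2)cc1`: 500 nM

In a functional assay on DU-145 cells (Homo sapiens) for cytotoxicity (a lower number here means a stronger inhibitor of growth, a higher number a weaker inhibitor of growth), compound 3 gives 500 nM, and its nearest neighbour, compound 2, gives 900 nM. These two values lie within the scatter of each other, and the only other result is the limit for compound 1.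

Compound 4 `COc1ccc(C2=C(c3ccc(SC)cc3)CC3CCCN3C2=O)cc1` has not been measured. It carries 4-methoxyphenyl in place of 3,4-difluorophenyl on a double-bonded ring carbon. Among the compounds with values here, the one measured step at this carbon is a 1.8-fold lower number from compound 2 to compound 3 (0.26 log units; within the scatter), where 3,4-difluorophenyl took the place of 4-methoxy-3-methylphenyl. A single step is thin evidence, but it gives no reason to expect a change beyond the scatter in this assay, and it sets no firm direction. The expected step is a 1.4-fold higher number from compound 3 to compound 4 (0.15 log units; within the scatter). For compound 4 the estimated value is 700 nM, with an expected range of 200 nM to 2500 nM.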

Compound 4, concentration for 50% growth inhibition: 900 nM
Compound 4: middle estimate off by 1.3-fold (0.11 log units), on the low side; the range from low to high includes it.
By their numbers in this assay, from the lowest: compounds 3, 2 and 4 (each within the scatter of the next). At a limit, above all of these: compound 1.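

In this assay, 4-methoxyphenyl in place of 3,4-difluorophenyl on the double-bonded ring carbon gives a 1.8-fold higher number from compound 3 to compound 4 (0.26 log units; within the scatter). Hydrogen in place of the methyl on that same phenyl group, an aromatic carbon, gives no change at the digits printed from compound 2 to compound 4 (within the scatter). With the 4-(methylsulfanyl)phenyl group kept, this carbon has now carried three different phenyl groups, and compounds 2, 3 and 4 all lie within the scatter of one another, so neither the fluorines, nor the methyl, sets these numbers apart.

The compounds shown leave open whether a group of another kind on this phenyl ring, such as an amine or a carboxylic acid, would take the number beyond the scatter. Nothing in the data available accounts for how closely these three values agree.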